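Cyclohexylamino to isopropylamino on the shared core

This account rests on a few compounds, and the source may have more. Where it says the series, first, only, none or still open, it means among the compounds named here.

Compound 1 `COc1cc(-c2nc3ccc(C)cn3c2NC2CCCCC2)ccc1OCCCNC(=O)Nc1ccc(C(F)(F)F)cc1` gives 439 nM in an assay for inhibition of Polyunsaturated fatty acid 5-lipoxygenase (Homo sapiens), read by HPLC, with a stated time of 15 min; a higher number here means a weaker inhibitor, a lower number a stronger inhibitor; compound 2 `COc1cc(-c2nc3ccc(F)cn3c2NC2CCCCC2)ccc1OCCCNC(=O)Nc1ccc(C(F)(F)F)cc1` gives 649 nM in this assay. Within the data shown here, the two lie within the scatter of each other, the only recorded step being a 1.5-fold higher number from compound 1 to compound 2 (0.17 log units; within the scatter). Compound 3 `COc1cc(-c2nc3ccc(C)cn3c2NC(C)C)ccc1OCCCNC(=O)Nc1ccc(C(F)(F)F)cc1` differs from compound 1 by isopropyl in place of cyclohexyl on a nitrogen on an aromatic ring. Among the measured compounds shown here, no measured step touches this nitrogen, and the one available step concerns the aromatic methyl only, so nothing in the data sets a direction for this assay. Compound 3 is expected to give about 900 nM, within 300 nM to 3000 nM, which means an expected step of a 2.1-fold higher number from compound 1 to compound 3 (0.31 log units; beyond the scatter).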

Compound 3, half-maximal inhibitory concentration: 620 nM
For compound 3 the middle estimate is 1.5-fold (0.16 log units) above the measured one; the measured number falls inside the stated range.
By their numbers in this assay, from the lowest: compounds 1, 3 and 2 (each within the scatter of the next).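

In this assay, isopropyl in place of cyclohexyl on a nitrogen on an aromatic ring gives a 1.4-fold higher number from compound 1 to compound 3 (0.15 log units; within the scatter) with the rest of compound 1 unchanged. This nitrogen therefore accepts an open-chain group in place of the six-membered non-aromatic ring without a step beyond the scatter, at least with methyl on the shared core. No evidence on hand bears on this result.

Still open, from the compounds shown here alone, is whether phenyl, a longer alkyl chain or a carboxylic acid on this nitrogen would keep the number in the same range. Also open, going by these compounds, is whether isopropyl behaves the same way with fluoro in place of methyl.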